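The compounds below may be only part of what the source reports. "The series", "measured", "known", "first", "only" and "open" are said of these compounds alone.

Series notes, step from compound 2 to compound 3.

Compound 1 `CCC1CCN(c2cc(C(F)(F)F)ccc2CNC(=O)C(C)c2ccc(NS(C)(=O)=O)c(F)c2)CC1` and compound 2 `CC(C(=O)NCc1ccc(C(F)(F)F)cc1N1CCC(C(F)(F)F)CC1)c1ccc(NS(C)(=O)=O)c(F)c1` share one core and differ only at a saturated ring carbon of the six-membered non-aromatic ring bearing one nitrogen. In an assay on CHO cells for antagonist activity at transient receptor potential cation channel subfamily V member 1 (Homo sapiens), read by FLIPR (on this read-out lower numbers stand for stronger inhibition and higher numbers for weaker inhibition), compound 1 gives 0.7 nM and compound 2 gives 0.4 nM. The step of a 1.8-fold lower number from compound 1 to compound 2 (0.24 log units; within the scatter) is the only measured one here. Compound 2 holds the lower of the two numbers, but as the step to compound 1 sits within the scatter, no order between the two is claimed.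

Compound 3 `CC(C(=O)NCc1ccc(C(F)(F)F)cc1N1CCC(Cc2ccccc2)CC1)c1ccc(NS(C)(=O)=O)c(F)c1` is not yet measured. It differs from compound 2 by benzyl in place of trifluoromethyl on a saturated ring carbon. Among the compounds with values here, only the step from compound 1 to compound 2 bears on this position, and it shows that exchanging ethyl for trifluoromethyl there left this assay essentially unchanged. Benzyl is a considerably larger group than either, and nothing measured tells how a group of that size is tolerated at this carbon, so the expectation is a small step of uncertain direction with wider error. For compound 3 the estimated value in this assay is 1.5 nM, range 0.4 nM to 6 nM. The step this estimate implies is a 3.8-fold higher number from compound 2 to compound 3 (0.57 log units; beyond the scatter), expected to stay near the scatter.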

Compound 3, inhibition constant: 1.4 nM
Compound 3: the middle estimate sits 1.1-fold (0.03 log units) above what was measured; the range from low to high includes it.
By their numbers in this assay, from the lowest: compounds 2, 1 and 3 (each within the scatter of the next, the first and the last beyond it).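

In this assay, within the data shown here, this saturated ring carbon, three ring bonds from the ring nitrogen, now carries a group with a six-membered aromatic ring, and a 3.5-fold higher number from compound 2 to compound 3 (0.54 log units; beyond the scatter) is the first step at this position beyond the scatter, though a modest one. Measured against ethyl, the same group gives a 2.0-fold higher number from compound 1 to compound 3 (0.30 log units; within the scatter), so the only separation among the three groups lies between trifluoromethyl and benzyl, while ethyl cannot be ordered against either. With 7 heavy atoms in benzyl against 4 in trifluoromethyl, the carbon still tolerates the larger group, as compound 3 gives 1.4 nM in this assay, but two steps of this size do not establish a trend with group size.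

Nothing available explains the size of these steps.

Still open, going by these compounds, is how a directly attached phenyl, or a longer chain such as 2-phenylethyl, would compare at this carbon with benzyl. Also open, on these data alone, is whether the aromatic ring itself matters, which cyclohexylmethyl could test, and how an amine or a carboxylic acid on the same carbon would read in this assay.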